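Nitro for hydroxy on the benzylamine arm of a chromone

The source may hold more compounds than are shown below. What is called first, only, known or untested is meant among the compounds shown, and "the series" means these compounds.

Four compounds share one core and differ only in the group on a benzyl ring. Compound 1 is `O=c1cc(CNCc2ccccc2O)oc2ccc(O)c(O)c12`, compound 2 is `O=c1cc(CNCc2ccccc2[N+](=O)[O-])oc2ccc(O)c(O)c12`, compound 3 is `O=c1cc(CNCc2cccc(O)c2)oc2ccc(O)c(O)c12` and the unmeasured compound 4 is `O=c1cc(CNCc2cccc([N+](=O)[O-])c2)oc2ccc(O)c(O)c12`. In an ADME assay on Huh-7 cells (Homo sapiens) for cytotoxicity (a lower number here means that less compound is tolerated, a higher number that more compound is tolerated), compound 1 gives only the limit > 100000 nM, not a number. In this assay compound 2 gives 41300 nM. Compound 3 gives only the limit > 100000 nM in this assay.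

The change from compound 1 to compound 2 is nitro in place of hydroxy on an aromatic carbon, and it gave an at least 2.4-fold lower number from compound 1 to compound 2 (0.38 log units; beyond the scatter). The two cores differ as 3-hydroxyphenyl in place of 2-hydroxyphenyl on a saturated chain carbon bound to an amine nitrogen, and the step that the two limits leave unreadable from compound 1 to compound 3 cannot be sized because of the limit of > 100000 nM in this assay, at which 2 of the 3 values shown sit. Compound 4 arises from compound 3 by nitro in place of hydroxy on an aromatic carbon, the same kind of change as that from compound 1 to compound 2, though there the nitro sits ortho to a large group and here meta to a large group.

For compound 4 a step like the earlier one is expected, an at least 2.2-fold lower number from compound 3 to compound 4 (0.34 log units; beyond the scatter), resting on compound 3 with > 100000 nM and on an at least 2.4-fold lower number from compound 1 to compound 2 (0.38 log units; beyond the scatter). Compound 4 is therefore estimated at 45000 nM in this assay.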

Compound 4, half-maximal cytotoxic concentration: > 100000 nM
Compound 4: no number, only a limit (the forecaster's own chance of this, stated with the estimate: 35%); middle value at least 2.2-fold (0.34 log units) away from the limit.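

Compound 3 and compound 4 both give only a limit, not a number, in this assay, so the step between them cannot be read: the limit of > 100000 nM in this assay, at which 3 of the 4 values shown sit.

The compounds shown leave open whether nitro in place of hydroxy, meta to a large group, changes the amount of compound tolerated at all.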